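A few compounds are considered here, and "the series" means these few. Any claim that something is new, unique, unknown or untested is made for them only; others in the source may bear on it.

Measured so far:
Compound 1 `O[C@@H](c1ccccc1)[C@H]1CO[C@H](c2ccccc2)[C@@H](C/C=C/c2ccccc2)C1`: 6060 nM
Compound 2 `COc1ccc(/C=C/C[C@@H]2C[C@@H]([C@@H](OC(C)=O)c3ccc(OC)c(OC)c3)CO[C@H]2c2ccc(OC)c(OC)c2)cc1OC`: > 100000 nM

Both compounds were tested in a functional assay on HeLa cells (Homo sapiens) for cytotoxicity, read by WST assay, with a stated time of 48 h; a higher number here means a weaker inhibitor, a lower number a stronger inhibitor. Going by the values given here, compound 1 gives 6060 nM, the only true number in this small set. Compound 2 reads > 100000 nM, which is a limit of the assay and not a number.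

Compound 3 `O[C@@H](c1ccccc1)[C@H]1CO[C@H](c2ccccc2)[C@@H](C/C=C/c2cccc(F)c2)C1` keeps the core of compound 1 and differs in one place: fluoro in place of hydrogen on an aromatic carbon. This is fluoro in place of hydrogen on an aromatic carbon, turning phenyl into 3-fluorophenyl. Among the compounds with values here, no measured pair here shows what such a change does, so the expectation rests on compound 1 at 6060 nM. The estimated step of a 1.2-fold lower number from compound 1 to compound 3 (0.08 log units; within the scatter) is expected to stay within the usual scatter, with no firm direction. For compound 3 the expected value in this assay is 5000 nM, with an estimated range of 2000 nM to 13000 nM.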

Compound 3, half-maximal inhibitory concentration: 8380 nM
Compound 3: middle estimate off by 1.7-fold (0.22 log units), on the low side; the measured number falls inside the stated range.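

In this assay, going by these compounds alone, the step of a 1.4-fold higher number from compound 1 to compound 3 (0.14 log units; within the scatter) gives the first reading of this change: fluoro in place of hydrogen on an aromatic carbon, which turns 3-phenylprop-2-en-1-yl into 3-(3-fluorophenyl)prop-2-en-1-yl. Within the data shown here, this place on the ring therefore takes a fluorine with no difference that can be told from the scatter, so the single swap leaves the reading of the core of compound 1 as it was. Nothing shown gives a cause for this result.

Still open, from the compounds shown here alone, is whether a nitrile or an amine at this same place would move the number beyond the scatter. One fluoro at one place also cannot tell whether a chlorine elsewhere on that ring would behave in the same way.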